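Adding a Methyl to the Isopropyl Chain of Compound 1

The source may hold more compounds than are shown below. What is called first, only, known or untested is meant among the compounds shown, and "the series" means these compounds.

Compound 1 `COc1ccc(-c2cc3cc(C4C(C#N)=C(N)OC5=C4C(=O)CC(C)(C)C5)cc(C(C)C)c3oc2=O)cc1` gives 64.9% in a functional assay on the whole organism (strain Swiss albino) with Mus musculus as the target, in the forced swim test, with a stated time of 5 min, at a dose of 0.5 mg/kg by the intraperitoneal route; on this read-out lower numbers stand for less inhibition and higher numbers for more inhibition at the one dose given (going by the name of the read-out).
Compound 2 `COc1ccc(-c2cc3cc(C4C(C#N)=C(N)OC5=C4C(=O)CC(C)(C)C5)cc(C(C)C)c3oc2=O)cc1OC` gives 86.6%.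
Compound 3 `COc1cc(-c2cc3cc(C4C(C#N)=C(N)OC5=C4C(=O)CC(C)(C)C5)cc(C(C)C)c3oc2=O)cc(OC)c1OC` gives 29.2%.

Among these three numbers compound 1 stands second highest: compound 2 lies above it by a number 21.7 percentage points higher from compound 1 to compound 2 (beyond the scatter), and compound 3 lies below it by a number 35.7 percentage points lower from compound 1 to compound 3 (beyond the scatter). Both steps are beyond the scatter. The remaining step is also of this kind: a number 57.4 percentage points lower from compound 2 to compound 3 (beyond the scatter).

Compound 4 `CCC(C)c1cc(C2C(C#N)=C(N)OC3=C2C(=O)CC(C)(C)C3)cc2cc(-c3ccc(OC)cc3)c(=O)oc12` keeps everything of compound 1 except one change: methyl in place of hydrogen on a saturated chain carbon, two bonds along the chain from an aromatic carbon. All three measured steps concern methoxy in place of hydrogen on an aromatic carbon, and none of them touches the isopropyl chain. So no measured step bears on the change from compound 1 to compound 4, and there is no basis for expecting a move in either direction beyond the scatter in this assay.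

Compound 4 is therefore expected to give 63%, between 42% and 82%. The expected step is a number 1.9 percentage points lower from compound 1 to compound 4 (within the scatter), which amounts to no change beyond the scatter; the range is wide, as nothing measured speaks to this chain.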

Compound 4, a percentage reported as inhibition, in the whole organism at one dose (the size of the read-out at that dose, not a potency): 26.9%
For compound 4 the middle estimate is 36.1 percentage points above the measured one, outside the stated range (below it).
By their numbers in this assay, from the lowest: compounds 4 and 3 (each within the scatter of the next); then compound 1; then compound 2.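

In this assay, a number 38 percentage points lower from compound 1 to compound 4 (beyond the scatter), so the isopropyl chain is far from a silent part of the molecule: turning isopropyl into sec-butyl, a change of just one methyl, moves the read-out well beyond the scatter. Going by these compounds alone, the earlier compounds showed only that methoxy groups on an aromatic ring can raise or lower this number, whereas this step shows that a saturated chain carbon, two bonds along the chain from an aromatic carbon, matters as well, and that here the added methyl goes with a lower number. Nothing available explains why so small a change has so large an effect in the whole animal.

The compounds shown leave open whether the number keeps falling as this chain grows, or whether it depends on the particular branching of sec-butyl, which a tert-butyl group, a straight n-butyl chain or a hydroxyl on the chain would help to separate. They also leave open whether the same swap from isopropyl to sec-butyl would lower the number as far on the core of compound 2, which carries the extra methoxy.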